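Removing the aryl trifluoromethyl from an inactive succinimide amide

The source may hold more compounds than are shown below. What is called first, only, known or untested is meant among the compounds shown, and "the series" means these compounds.

Compound 3 `CCC(C(=O)N1CCN(c2ccc(C(F)(F)F)cc2)CC1)N1C(=O)CCC1=O` was tested in a functional assay on the whole organism (strain Swiss) with Mus musculus as the target, in the maximal electroshock model, with a stated time of 2 h, at a dose of 300 mg/kg by the intraperitoneal route (a lower number here means a weaker effect, a higher number a stronger effect of the compound at the dose given), where compound 3 gives 0%. Compound 2 `CC(C(=O)N1CCN(c2ccc(C(F)(F)F)cc2)CC1)N1C(=O)CCC1=O` gives 0% in this assay, and the step of no change at the digits printed from compound 2 to compound 3 (within the scatter) shows that methyl in place of hydrogen on the saturated chain carbon made no difference. Together compound 2 and compound 3 stand at the lowest of the three numbers seen; compound 1 `COCC(C(=O)N1CCN(c2cccc(C(F)(F)F)c2)CC1)N1C(=O)CCC1=O` gives 100%, but compound 1 differs from both in more than one place, so no single step can be drawn from it.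

Compound 4 `CCC(C(=O)N1CCN(c2ccccc2)CC1)N1C(=O)CCC1=O` differs from compound 3 only at the aromatic ring: hydrogen in place of trifluoromethyl on an aromatic carbon. Within the data shown here, no measured step bears on this change; the only step measured touches the chain and was flat. What the values of compound 1 beside compound 2 and compound 3 show is that large swings occur within this small set, so an upward move is possible but uncertain. Compound 4 is therefore expected to show only a modest gain, a number 20 percentage points higher from compound 3 to compound 4 (beyond the scatter), with the estimate for compound 4 at 20% and a range from 0% to 65%.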

Compound 4, a percentage reported as activity, at one dose (the size of the read-out at that dose, not a potency): 25%
For compound 4 the middle estimate is 5 percentage points below the measured one, and the stated range covers the measured number.
By their numbers in this assay, from the lowest: compounds 2 and 3 (each within the scatter of the next); then compound 4; then compound 1.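

Among these compounds, the aromatic carbon para to a large group is the first place in this set where a single change moves the number in this assay: hydrogen in place of trifluoromethyl gives a number 25 percentage points higher from compound 3 to compound 4 (beyond the scatter) on the same core. Among the compounds shown here, the only earlier step, no change at the digits printed from compound 2 to compound 3 (within the scatter) on the saturated chain, had been flat, so the aromatic ring now stands as a position that can shift this read-out, although only by a modest step. No measurement here offers an explanation for the rise.

As far as these compounds go, whether the same exchange would raise the number on the core of compound 2 remains open. So does what a chlorine atom or a methoxy group on this aromatic carbon would give, as one step cannot show whether other groups there would behave like hydrogen or like trifluoromethyl.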